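The source may report more compounds than this note shows. Statements on the series, on what has been measured and on what is new or still open speak of the compounds shown alone.

Of the compounds shown here, two have so far been measured in an ADME assay on MT2 cells (Homo sapiens) for cytotoxicity, read by XTT assay, with a stated time of 4 days; a lower number here means that less compound is tolerated, a higher number that more compound is tolerated. Compound 1, `Cc1ccc(C)n1-c1ccc(S(N)(=O)=O)cc1`, gives 117000 nM in this assay. Compound 2, `COC(=O)c1ccc(-c2noc(CCl)n2)cc1`, gives 14200 nM in this assay, the lowest of the two numbers; its gap to compound 1 lies beyond the usual scatter of repeated measurements, so compound 2 is the less tolerated of the pair. Compound 3, `O=C(O)c1ccc(-c2noc(CCl)n2)cc1`, has not yet been measured. It differs from compound 2 in one place: hydrogen in place of methyl on an oxygen next to a carbonyl group. Among the measured compounds shown here, no pair of measured compounds is related by a single change of this kind, so there is no directly comparable step to lean on, and any expectation rests on the structural change alone. The expectation in this assay is a step upward from compound 2 to compound 3, of moderate size and possibly not larger than the scatter, meaning that somewhat more of compound 3 is expected to be tolerated. The estimated step is a 2.1-fold higher number from compound 2 to compound 3 (0.32 log units; beyond the scatter). For compound 3 the expected value in this assay is 30000 nM, with a range from 10000 nM to 100000 nM.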

Compound 3, half-maximal cytotoxic concentration: 64000 nM
Compound 3: middle estimate off by 2.1-fold (0.33 log units), on the low side, within the range that was stated.
By their numbers in this assay, from the lowest: compound 2; then compounds 3 and 1 (each within the scatter of the next).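

In this assay, putting hydrogen in place of methyl on an oxygen next to a carbonyl group, which turns methoxycarbonyl into carboxy, gives a 4.5-fold higher number from compound 2 to compound 3 (0.65 log units; beyond the scatter), a modest step that lies beyond the scatter. Among the compounds shown here, this is the first comparison in the set that isolates a single change, and it shows that this position is not silent: with the rest of the structure held constant, losing one methyl is enough to shift the tolerated concentration upward. The data show only the size and direction of this step, and nothing measured here accounts for it.

As far as these compounds go, it remains open whether the step depends on having hydrogen at this position or whether other replacements for the methyl, such as an ethyl group or a longer chain, would also shift the number, and where a carboxamide in place of the carboxy group would fall. Also unsettled is whether the same change from methoxycarbonyl to carboxy would give a similar step on a different core.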